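Benzoxazolone amines: swapping the benzyl aryl substituent

The source may report more compounds than this note shows. Statements on the series, on what has been measured and on what is new or still open speak of the compounds shown alone.

Compound 1 `Cc1ccc(CN(C)CCCn2c(=O)oc3ccccc32)c(C)c1` and compound 2 `Cc1cccc(CN(C)CCCn2c(=O)oc3ccccc32)c1` share a core with compound 3 `COc1ccccc1CN(C)CCCCn1c(=O)oc2ccccc21` and differ from it in the aryl group on the benzylic carbon. In an assay on membranes from liver for displacement of a labelled ligand from Sigma non-opioid intracellular receptor 1 (Rattus norvegicus), read by scintillation counting (a higher number here means a weaker inhibitor, a lower number a stronger inhibitor), compound 1 gives 1830 nM and compound 2 gives 1840 nM; the step of a 1.0-fold higher number from compound 1 to compound 2 (0.00 log units; within the scatter) shows that moving and removing a methyl on that aryl ring leaves the number essentially unchanged. For the measured compounds named here, compound 3 gives 594 nM, the lowest of the three numbers, beyond the scatter from both compound 1 and compound 2; no single-place step links compound 3 to either, so only the values themselves are compared.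

Compound 4 `Cc1ccc(CN(C)CCCCn2c(=O)oc3ccccc32)cc1` is not yet measured. Its change from compound 3 is 4-methylphenyl in place of 2-methoxyphenyl on a saturated chain carbon bound to an amine nitrogen. Going by the values given here, the only measured step on this part of the molecule, from compound 1 to compound 2, lies within the scatter, so a small step is expected here too, if anything toward a higher number in this assay. Compound 4 is estimated at 900 nM, between 400 nM and 2500 nM, an expected step of a 1.5-fold higher number from compound 3 to compound 4 (0.18 log units; within the scatter).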

Compound 4, inhibition constant: 97 nM
Beside the measured number, compound 4's estimate is 9.3-fold (0.97 log units) above it; measured number outside the range, below it.
By their numbers in this assay, from the lowest: compound 4; then compound 3; then compounds 1 and 2 (each within the scatter of the next).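

In this assay, the aryl group on a saturated chain carbon bound to an amine nitrogen now shows a real effect: 4-methylphenyl in place of 2-methoxyphenyl gives a 6.1-fold lower number from compound 3 to compound 4 (0.79 log units; beyond the scatter). The earlier step, a 1.0-fold higher number from compound 1 to compound 2 (0.00 log units; within the scatter), stayed within the scatter, so that pair alone gave no sign that this position responds to a change of aryl group. No measurement on hand bears on what lies behind the new step.

The new step changes both the substituent and its place on the ring, and the compounds shown do not separate the two. A 4-methoxyphenyl or 2-methylphenyl group on the same carbon would tell them apart, and a 4-chlorophenyl group would show whether the lower number is specific to methyl.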